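A Long Plain Chain in Place of an Ether Tail

The source may report more compounds than this note shows. Statements on the series, on what has been measured and on what is new or still open speak of the compounds shown alone.

Of the compounds shown here, two have so far been measured in an in vitro ADME assay on microsomes from liver (Mus musculus) for metabolic stability, tested at 0.2 uM; a lower number here means slower removal, a higher number faster removal of the compound.

Compound 1, `Cc1c(COc2ccnc(OCC3CCOCC3)c2)[nH]c2ccccc2c1=O`, gives 203 mL/min/kg.
Compound 2, `COCCOCCCCc1[nH]c2ccccc2c(=O)c1C`, gives > 1000 mL/min/kg, which is a limit of the assay and not a number.

Compound 2 therefore stands at the limit of > 1000 mL/min/kg in this assay, at which 1 of the 2 values shown sits; the assay reports only that its clearance lies beyond what can be quantified, so no exact figure is known for it.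

Compound 3, `CCCCCCCCCc1[nH]c2ccccc2c(=O)c1C`, differs from compound 2 in one place: pentyl in place of 2-methoxyethoxy on a saturated chain carbon, four bonds along the chain from an aromatic carbon. Compound 2 offers only a limit as a starting point, so the size of the step cannot be read from its value; the expectation is that compound 3 changes little from it, with a step that the limit leaves unreadable from compound 2 to compound 3, no larger than the usual scatter. Compound 3 is therefore expected to give about 1200 mL/min/kg, within a range from 500 mL/min/kg to 3000 mL/min/kg.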

Compound 3, clearance in the liver assay: > 1000 mL/min/kg
Compound 3: only a limit was reported; the forecaster's own chance of this, stated with the estimate: 65%; the middle value lies beyond the limit too.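

Within the data shown here, in the liver assay compound 2 and compound 3 both stand at a limit of the assay, and no step between them can be read. In a physicochemical assay for solubility, at pH 6.8 (on this read-out lower numbers stand for lower solubility and higher numbers for higher solubility), compound 2 gives >= 100000 nM, a limit and not a number. In the physicochemical assay compound 3 gives < 1000 nM, again a limit. Still open, as far as these compounds go, is how far beyond the limit the clearance of compound 2 and compound 3 lies.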